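Chloro for amino on two related purine-like cores

The compounds below may be only part of what the source reports. "The series", "measured", "known", "first", "only" and "open" are said of these compounds alone.

The study compares four compounds in an ADME assay on L1210/0 cells (Mus musculus) for cytotoxicity, with a stated time of 48 h; on this read-out higher numbers stand for weaker inhibition and lower numbers for stronger inhibition. Compound 1, `Nc1nc(Cl)c2nnn([C@H]3CCCC[C@H]3CO)c2n1`, carries a chloro group on the shared core and gives 95500 nM in this assay. Compound 2, `Nc1nc(N)c2nnn([C@H]3CCCC[C@H]3CO)c2n1`, carries an amino group in that place instead. In this assay compound 2 reaches only a limit of the assay, > 200000 nM. Compound 3, `CC1(C)[C@@H](CCCO)C[C@H]1n1nnc2c(N)nc(N)nc21`, bears the same two amino groups on a different core. Compound 3 also reports only a limit of the assay in this assay, > 200000 nM. How the two cores differ is not broken down here. Compound 3 stands at the limit of > 200000 nM in this assay, at which 2 of the 3 values shown sit.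

The change from compound 2 to compound 1 is chloro in place of amino on an aromatic carbon, and it gives an at least 2.0-fold lower number from compound 2 to compound 1 (0.32 log units; beyond the scatter). Compound 4, `CC1(C)[C@@H](CCCO)C[C@H]1n1nnc2c(Cl)nc(N)nc21`, is not yet measured; it arises from compound 3 by chloro in place of amino on an aromatic carbon, the same change made on the other core.

Because compound 3 sits only at a limit of the assay, > 200000 nM, the starting point for compound 4 is uncertain. Compound 4 is expected to show an at least 1.6-fold lower number from compound 3 to compound 4 (0.22 log units; that floor lies within the scatter) in this assay, resting on an at least 2.0-fold lower number from compound 2 to compound 1 (0.32 log units; beyond the scatter). The estimated value for compound 4 in this assay is 120000 nM, with a range from 50000 nM to 300000 nM, and a fair chance that only a limit is reported.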

Compound 4, half-maximal inhibitory concentration: > 200000 nM
Compound 4: no number, only a limit (the forecaster's own chance of this, stated with the estimate: 40%); middle value at least 1.6-fold (0.22 log units) away from the limit.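

In this assay compound 4 reports only a limit of the assay, > 200000 nM. Compound 3 also reports only a limit, > 200000 nM, and the step from compound 3 to compound 4 cannot be read from these two limits. The compounds shown leave open whether chloro in place of amino on an aromatic carbon changes the number at all on the core of compound 3.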